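The compounds below may be only part of what the source reports. "The series", "measured", "known", "first", "only" and "open" are said of these compounds alone.

Measured compounds:
- compound 1, `COc1cccc(/C=C/C(=O)Nc2cc(C(=O)c3cc(OC)c(OC)c(OC)c3)ccc2OC)c1`: 4700 nM
- compound 2, `COc1cccc(/C=C/C(=O)Nc2cc(C(=O)c3cc(OC)c(OC)c(OC)c3)cc(OC)c2OC)c1`: 13300 nM

Compound 2 gives the highest of the two numbers in a functional assay on PC-3 cells (Homo sapiens) for cytotoxicity, read by MTT assay, with a stated time of 72 h; a lower number here means a stronger inhibitor, a higher number a weaker inhibitor. Going by the values given here, its nearest neighbour is compound 1, and the step of a 2.8-fold higher number from compound 1 to compound 2 (0.45 log units; beyond the scatter) is the only one measured so far.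

Compound 3, `COc1cc(C(=O)c2cc(OC)c(OC)c(OC)c2)cc(NC(=O)/C=C/c2ccc(C(F)(F)F)cc2)c1OC`, is not yet measured. It differs from compound 2 in this way: 4-(trifluoromethyl)phenyl in place of 3-methoxyphenyl on a double-bonded chain carbon bound to a double-bonded chain carbon. Among the compounds with values here, the one measured step, from compound 1 to compound 2, concerns the substitution on the shared core and not the aryl on the double-bonded chain, so it does not bear on this change. Within the data shown here, no measured pair shows what swapping the aryl at that position does. With nothing to lean on, no step beyond the scatter is expected in either direction, and the estimate is anchored on compound 2 while the range is kept wide.

The expected step of a 1.0-fold lower number from compound 2 to compound 3 (0.01 log units; within the scatter) is therefore taken as flat. Compound 3 is estimated at 13000 nM in this assay, with a range from 4000 nM to 40000 nM.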

Compound 3, half-maximal inhibitory concentration: 4200 nM
Beside the measured number, compound 3's estimate is 3.1-fold (0.49 log units) above it; the measured number falls inside the stated range.
By their numbers in this assay, from the lowest: compounds 3 and 1 (each within the scatter of the next); then compound 2.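

In this assay the aryl on a double-bonded chain carbon bound to a double-bonded chain carbon is not a silent position: 4-(trifluoromethyl)phenyl in place of 3-methoxyphenyl gives a stronger inhibitor (a 3.2-fold lower number from compound 2 to compound 3 (0.50 log units; beyond the scatter)). Going by these compounds alone, this modest step is the first reading on this part of the molecule, as the earlier pair spoke only to the shared core. The swap removes a methoxy group and brings in a trifluoromethyl group at once, so the step belongs to the exchange as a whole and cannot be assigned to either group alone, and no measurement at hand accounts for it.

As far as these compounds go, it remains open whether the same exchange gives a step of like size on the core of compound 1, and whether losing the methoxy group or gaining the trifluoromethyl group carries the effect, a question that a plain phenyl at this place would help to separate. Also open is how the series reads with a phenyl carrying an amine or a carboxylic acid on that chain carbon, as the two aryl groups shown span only a narrow range of substituents.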